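Fluoro on the anilino ring of compound 1

The source may hold more compounds than are shown below. What is called first, only, known or untested is meant among the compounds shown, and "the series" means these compounds.

Compound 1 `CNC(=O)c1cc(Oc2ccc3nc(Nc4ccccc4)ncc3c2)ccn1` is one of three close analogues that share a core and differ only in the substituent carried on the anilino ring. In an ADME assay on Caco-2 cells (Homo sapiens) for permeability, in the apical to basolateral direction (a lower number here means that the compound crosses the layer more slowly, a higher number that the compound crosses the layer faster), compound 1 gives < 1 10^-6 cm/s, which is a limit of the assay and not a number. Compound 2 `CCc1ccccc1Nc1ncc2cc(Oc3ccnc(C(=O)NC)c3)ccc2n1` is the ethyl analogue; in this assay compound 2 gives < 1 10^-6 cm/s, again a limit. Compound 3 `CNC(=O)c1cc(Oc2ccc3nc(Nc4cccc(C(C)C)c4)ncc3c2)ccn1` is the isopropyl analogue; in this assay compound 3 gives < 1 10^-6 cm/s, also a limit. The steps a step that the two limits leave unreadable from compound 1 to compound 2 and a step that the two limits leave unreadable from compound 1 to compound 3 therefore cannot be sized, and the same holds for a step that the two limits leave unreadable from compound 2 to compound 3; all that the three measurements show is the limit of < 1 10^-6 cm/s in this assay, at which 3 of the 3 values shown sit.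

Compound 4 `CNC(=O)c1cc(Oc2ccc3nc(Nc4ccc(F)cc4)ncc3c2)ccn1` differs from compound 1 by fluoro in place of hydrogen on an aromatic carbon. Among the measured compounds shown here, none of the measured steps gives a readable change for any substitution on the anilino ring, and no measured step involves fluoro at all. With every value shown sitting at the limit, the expectation is that compound 4 also returns a value at or close to that limit, so that the step that the limit leaves unreadable from compound 1 to compound 4 is expected to be small. Compound 4 is accordingly estimated at 0.5 10^-6 cm/s, within a range from 0.1 10^-6 cm/s to 2 10^-6 cm/s.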

Compound 4, apparent permeability: < 1 10^-6 cm/s
Compound 4 ended at the assay's limit; the forecaster's own chance of this, stated with the estimate: 80%; the middle value is on the limit's open side.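

In this assay compound 4 gives < 1 10^-6 cm/s, a limit of the assay and not a number, so its steps from compound 1, compound 2 and compound 3 cannot be read. The compounds shown leave open whether fluoro, ethyl or isopropyl on the anilino ring changes the apparent permeability at all, and all that can be stated is this: the limit of < 1 10^-6 cm/s in this assay, at which 4 of the 4 values shown sit.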